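This account rests on a few compounds, and the source may have more. Where it says the series, first, only, none or still open, it means among the compounds named here.

Compound 1 `COc1cc(-c2cc(C(=O)O)c3ccccc3n2)ccc1OCC(=O)Nc1ccccc1C` gives 0.8 in a physicochemical assay for lipophilicity, using the shake flask method, in phosphate buffer, measured as octanol-water partition, at pH 7.4; on this read-out lower numbers stand for lower lipophilicity and higher numbers for higher lipophilicity.
Compound 2 `COc1cc(-c2cc(C(=O)O)c3ccccc3n2)ccc1OCC(=O)Nc1cccc(C)c1` gives 1.5 in this assay.
Compound 3 `COc1cc(-c2cc(C(=O)O)c3ccccc3n2)ccc1OCC(=O)NCc1ccccc1` gives 0.4 in this assay.

Compound 3 stands lowest of the three numbers; compound 1 is nearest to it and compound 2 furthest, both beyond the scatter. Compound 4 `COc1cc(-c2cc(C(=O)O)c3ccccc3n2)ccc1OCC(=O)NCc1ccco1` differs from compound 3 by furan-2-yl in place of phenyl on a saturated chain carbon bound to an amide-type nitrogen. The measured steps all concern the group on the amide-type nitrogen: a number 0.70 log units higher from compound 1 to compound 2 (beyond the scatter), a number 0.40 log units lower from compound 1 to compound 3 (beyond the scatter) and a number 1.10 log units lower from compound 2 to compound 3 (beyond the scatter). Among the measured compounds shown here, none of them exchanges the phenyl of the benzyl for another ring, so the present change has no direct precedent; a modest step downward is nevertheless expected, a number 0.60 log units lower from compound 3 to compound 4 (beyond the scatter). Compound 4 is estimated at -0.2, with a range from -0.7 to 0.3.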

Compound 4, distribution coefficient: -0.3
Beside the measured number, compound 4's estimate is 0.10 log units above it, within the range that was stated.
By their numbers in this assay, from the lowest: compound 4; then compound 3; then compound 1; then compound 2.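

Exchanging the ring itself also moves the number: in this assay furan-2-yl in place of phenyl on the saturated chain carbon gives a number 0.70 log units lower from compound 3 to compound 4 (beyond the scatter). Against the methylphenyl amides, (furan-2-yl)methyl gives a number 1.80 log units lower from compound 2 to compound 4 (beyond the scatter) and a number 1.10 log units lower from compound 1 to compound 4 (beyond the scatter), widening the spread seen so far at the amide-type nitrogen. Nothing available accounts for these steps.

From the compounds shown here alone, whether thiophen-2-yl, a five-membered ring with sulfur for oxygen, gives a similar step remains open. So does the outcome for a longer chain carrying furan-2-yl.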